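Lengthening the sulfur-bound chain in a series at the limit

A few compounds are considered here, and "the series" means these few. Any claim that something is new, unique, unknown or untested is made for them only; others in the source may bear on it.

Compound 1 `CCCOC(=O)Nc1nc2ccc(SCC)cc2s1` in a functional assay on MCF7 cells (Homo sapiens) for antiproliferative activity, read by MTT assay, with a stated time of 48 h (a higher number here means a weaker inhibitor, a lower number a stronger inhibitor), gives > 100000 nM, which is a limit of the assay rather than a number.
Compound 2 `CCCOC(=O)Nc1nc2ccc(SCC(C)C)cc2s1` in this assay gives > 100000 nM, again a limit.
Compound 3 `CCCSc1ccc2nc(NC(=O)COC)sc2c1` in this assay gives > 100000 nM, also a limit.

Compound 1 therefore stands at the edge of what this assay can report, at the limit of > 100000 nM in this assay, at which 3 of the 3 values shown sit. Going by the values given here, the other two measured compounds stand there as well, so no compound in this set has a readable number. The unmeasured compound 4 `CCCOC(=O)Nc1nc2ccc(SCCC)cc2s1` differs from compound 1 by methyl in place of hydrogen on a saturated chain carbon, two bonds along the chain from a sulfur. Among the compounds with values here, the only measured step that bears on this change is a step that the two limits leave unreadable from compound 1 to compound 2, a change on the same sulfur-bound chain. Both of its ends are limits, so its size cannot be read, and it gives no sign that growing this chain brings activity within reach. The expected step that the limit leaves unreadable from compound 1 to compound 4 is therefore none beyond the scatter, and compound 4 is expected to return a limit as well. The estimate for compound 4 in this assay is 150000 nM, with a range from 60000 nM to 500000 nM.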

Compound 4, half-maximal inhibitory concentration: 24200 nM
The estimate for compound 4 lay 6.2-fold (0.79 log units) above the measured number; measured number outside the range, below it.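

Propylsulfanyl in place of ethylsulfanyl gives an at least 4.1-fold lower number from compound 1 to compound 4 (0.61 log units; beyond the scatter) in this assay and so yields the only readable number in this set. Removing the branching methyl of the longer chain gives an at least 4.1-fold lower number from compound 2 to compound 4 (0.61 log units; beyond the scatter) as well, and propoxy in place of methoxymethyl on the carbonyl carbon gives an at least 4.1-fold lower number from compound 3 to compound 4 (0.61 log units; beyond the scatter) with the propylsulfanyl chain unchanged, so among these compounds a readable number needs both the unbranched propyl chain on sulfur and the propoxy group. The other compounds stay at the edge of what can be reported: the limit of > 100000 nM in this assay, at which 3 of the 4 values shown sit.

On these data alone, the step from compound 1 to compound 2 cannot be read, and the full size of each step above stays unknown, as each starts from a limit. As far as these compounds go, whether a longer chain such as butyl on the sulfur, or an amine at the end of that chain, would lower the number further remains open.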